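Effect of a Ring Methyl on Cell Growth Inhibition

The source may report more compounds than this note shows. Statements on the series, on what has been measured and on what is new or still open speak of the compounds shown alone.

Measured compounds:
Compound 1 `N/C(=N\NC(=S)N1CCOCC1)c1ccccn1` gives 43.1%
Compound 2 `Cc1ccnc(/C(N)=N/NC(=S)N2CCSCC2)c1` gives 34.7%

Of the compounds shown here, two have been tested in a functional assay on A-431 cells (Homo sapiens) for cytotoxicity, read by MTT assay, with a stated time of 72 h, tested at 3 uM; a higher number here means more inhibition of growth at the concentration tested, a lower number less inhibition of growth. Compound 1 gives 43.1%, and compound 2 gives 34.7% in this assay. The two numbers differ by an amount that falls within the usual scatter of such measurements, so neither compound can be placed apart from the other on these data. Compound 2 thus stands alongside compound 1, with nothing beyond the scatter to separate them.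

Compound 3 `N/C(=N\NC(=S)N1CCSCC1)c1ccccn1` has not yet been measured. It differs from compound 2 by hydrogen in place of methyl on an aromatic carbon. No step between measured compounds isolates this particular change, so its effect is not known from the numbers shown. Given that compound 1 and compound 2 sit within the scatter of each other despite differing in two places, the step from compound 2 to compound 3 is expected to be small, with no direction beyond the scatter, namely a number 3.3 percentage points higher from compound 2 to compound 3 (within the scatter). Compound 3 is therefore estimated to give 38% in this assay, within a range from 25% to 52%.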

Compound 3, percent growth inhibition at one concentration: 37.2%
Compound 3: middle estimate off by 0.8 percentage points, on the high side; the range from low to high includes it.
By their numbers in this assay, from the lowest: compounds 2, 3 and 1 (each within the scatter of the next).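

The methyl position now has its first reading in one place: with hydrogen in place of methyl on the aromatic carbon opposite the ring nitrogen, this assay shows a number 2.5 percentage points higher from compound 2 to compound 3 (within the scatter), so on these data methyl and hydrogen at this position cannot be told apart. Going by these compounds alone, compound 3 also gives the first reading of the other place, where thiomorpholin-4-yl stands in place of morpholin-4-yl on the thiocarbonyl carbon, with a number 5.9 percentage points lower from compound 1 to compound 3 (within the scatter), so the two differences between compound 1 and compound 2 can now be read separately and neither change stands beyond the scatter. No measurement is available that would explain either step.

What the compounds shown leave open is whether any group other than methyl at this position, such as a methoxy group, a chlorine atom, an amine or a carboxylic acid, would move the growth inhibition beyond the scatter. On these data alone, it also remains open whether a piperidin-1-yl or a piperazin-1-yl ring on the thiocarbonyl carbon would separate from the morpholin-4-yl and thiomorpholin-4-yl rings in this assay.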